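Swapping chloro for methoxy on the anilino ring

The source may hold more compounds than are shown below. What is called first, only, known or untested is meant among the compounds shown, and "the series" means these compounds.

Compound 1, `COc1ccc(-c2nc(C(=O)/C=C\Nc3ccc4[nH]ccc4c3)c3ccccn23)cc1`, gives 28700 nM in a functional assay on MDA-MB-231 cells (Homo sapiens) for cytotoxicity, read by MTT assay, with a stated time of 48 h; on this read-out lower numbers stand for stronger inhibition and higher numbers for weaker inhibition.
Compound 2, `COc1ccc(N/C=C\C(=O)c2nc(-c3ccc(F)cc3)n3ccccc23)cc1`, gives only a limit in this assay, > 30000 nM.
Compound 3, `COc1ccc(-c2nc(C(=O)/C=C\Nc3ccc(Cl)cc3)c3ccccn23)cc1`, likewise gives only a limit in this assay, > 30000 nM.

Compound 3 therefore sits at the limit of > 30000 nM in this assay, at which 2 of the 3 values shown sit, with no number of its own. Compound 4, `COc1ccc(N/C=C\C(=O)c2nc(-c3ccc(OC)cc3)n3ccccc23)cc1`, is not yet measured; it differs from compound 3 by methoxy in place of chloro on an aromatic carbon. Among the compounds with values here, the one measured step on this part of the molecule is an at least 1.0-fold higher number from compound 1 to compound 3 (0.01 log units; that floor lies within the scatter), a move from a weak number onto the limit. Compound 2 already carries the (4-methoxyphenyl)amino group and also reaches only a limit. Compound 4 is therefore expected at 40000 nM, between 15000 nM and 150000 nM, most likely again as a limit. The expected step is a step that the limit leaves unreadable from compound 3 to compound 4.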

Compound 4, half-maximal inhibitory concentration: > 30000 nM
Compound 4 gave a limit, no number; the forecaster's own chance of this, stated with the estimate: 70%; the middle value is on the limit's open side.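

With chloro or with methoxy on this aromatic carbon, this assay gives no number, only a limit. Within the data shown here, the steps from compound 3 and from compound 2 to compound 4 cannot be read, and the one readable step is an at least 1.0-fold higher number from compound 1 to compound 4 (0.01 log units; that floor lies within the scatter), with 4-methoxyphenyl in place of 1H-indol-5-yl on the amine nitrogen. Most of the series now rests on a single limit: the limit of > 30000 nM in this assay, at which 3 of the 4 values shown sit.

From the compounds shown here alone, how far compound 2, compound 3 and compound 4 lie past that limit stays unknown, so chloro, fluoro and methoxy cannot be ranked. Also open, going by these compounds, is whether an amine or a carboxylic acid on this aromatic carbon would give a readable number.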